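Swapping Butyl for tert-Butyl in Compound 3

A few compounds are considered here, and "the series" means these few. Any claim that something is new, unique, unknown or untested is made for them only; others in the source may bear on it.

In a functional assay on HeLa cells (Homo sapiens) for antiproliferative activity, read by MTT assay, with a stated time of 96 h (a lower number here means a stronger inhibitor, a higher number a weaker inhibitor), compound 1 `O=C1C2=C(C(=O)c3ncccc31)C1(CS2)NC(=O)N(c2ccc(Cl)cc2)C1=O` gives 2 nM, compound 2 `O=C1NC(=O)C2(CSC3=C2C(=O)c2ncccc2C3=O)N1` gives 150 nM and compound 3 `CCCCc1ccc(N2C(=O)NC3(CSC4=C3C(=O)c3ncccc3C4=O)C2=O)cc1` gives 90 nM. Hydrogen in place of 4-chlorophenyl gives a 75-fold higher number from compound 1 to compound 2 (1.88 log units; beyond the scatter), and 4-butylphenyl in place of hydrogen gives a 1.7-fold lower number from compound 2 to compound 3 (0.22 log units; within the scatter). Compound 3 thus stands level with compound 2 and far above compound 1. Compound 4 `CC(C)(C)c1ccc(N2C(=O)NC3(CSC4=C3C(=O)c3ncccc3C4=O)C2=O)cc1` has tert-butyl in place of butyl on an aromatic carbon. The nearest guide, a 45-fold higher number from compound 1 to compound 3 (1.65 log units; beyond the scatter), replaced chloro rather than one chain with another, so it mainly warns that this position can matter. A small change with no firm direction is expected, namely a 1.5-fold lower number from compound 3 to compound 4 (0.18 log units; within the scatter). For compound 4 the estimated value is 60 nM, with an expected range of 10 nM to 250 nM.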

Compound 4, half-maximal inhibitory concentration: 100 nM
Compound 4: middle estimate off by 1.7-fold (0.22 log units), on the low side; the range from low to high includes it.
By their numbers in this assay, from the lowest: compound 1; then compounds 3, 4 and 2 (each within the scatter of the next).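

In this assay, rearranging the chain leaves the number unmoved (a 1.1-fold higher number from compound 3 to compound 4 (0.05 log units; within the scatter)), so butyl and tert-butyl cannot be told apart at this position. Compound 4 also stays level with the compound lacking the aryl group (a 1.5-fold lower number from compound 2 to compound 4 (0.18 log units; within the scatter)), while tert-butyl in place of chloro gives a large step (a 50-fold higher number from compound 1 to compound 4 (1.70 log units; beyond the scatter)), so both chains fall well short of chloro here. Nothing available explains this.

Still open, from the compounds shown here alone, is whether fluoro, bromo or methoxy on that aromatic carbon would give a number as low as chloro does.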